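The source may hold more compounds than are shown below. What is called first, only, known or untested is meant among the compounds shown, and "the series" means these compounds.

Compound 1 `CCOC(=O)C1=C(N)Oc2ccccc2C1C(C#N)C(=O)OCC` gives 66000 nM in a functional assay on Jurkat cells (Homo sapiens) for inhibition (a lower number here means a stronger inhibitor of growth, a higher number a weaker inhibitor of growth), the highest number among the three compounds measured there. Compound 2 `CCOC(=O)C1=C(N)Oc2ccc(C)cc2C1C(C#N)C(=O)OCC` gives 29000 nM, and compound 3 `CCOC(=O)C1=C(N)Oc2ccc(CC)cc2C1C(C#N)C(=O)OCC` gives 13000 nM. Compound 4 `CCOC(=O)C1=C(N)Oc2ccc(-c3ccccc3)cc2C1C(C#N)C(=O)OCC` has not yet been measured. It differs from compound 1 in one place: phenyl in place of hydrogen on an aromatic carbon.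

Going by the values given here, two measured steps bear on this change, both at the same aromatic carbon of the shared core. There is a 2.3-fold lower number from compound 1 to compound 2 (0.36 log units; beyond the scatter) and a 5.1-fold lower number from compound 1 to compound 3 (0.71 log units; beyond the scatter), and between the two substituted compounds a 2.2-fold lower number from compound 2 to compound 3 (0.35 log units; beyond the scatter). Each growth of the group at that carbon has brought a lower number, so the phenyl entering in compound 4 is expected to continue in the same direction, likely at least matching the ethyl step. The expectation rests on three compounds only, so the range is kept wide. Compound 4 is therefore estimated to give 8000 nM in this assay, within a range from 2500 nM to 25000 nM. The expected step is an 8.3-fold lower number from compound 1 to compound 4 (0.92 log units; beyond the scatter).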

Compound 4, concentration for 50% growth inhibition: 3900 nM
Compound 4: middle estimate off by 2.1-fold (0.31 log units), on the high side; low and high end bracket the measured number.
By their numbers in this assay, from the lowest: compound 4; then compound 3; then compound 2; then compound 1.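

In this assay, the fall in the numbers at this aromatic carbon does not end with the small alkyl groups: phenyl continues it and gives the largest step seen at this position (a 17-fold lower number from compound 1 to compound 4 (1.23 log units; beyond the scatter)). Phenyl also goes beyond both alkyl groups (a 3.3-fold lower number from compound 3 to compound 4 (0.52 log units; beyond the scatter); a 7.4-fold lower number from compound 2 to compound 4 (0.87 log units; beyond the scatter)), so across the four compounds the number falls with each larger group at this carbon, and none of them goes against that order. No measurement shown explains this order.

Going by these compounds, it remains open whether the aromatic ring itself matters or only the added carbon, which a cyclohexyl group or a butyl chain at this carbon could separate. Also open, on these data alone, is whether the order holds for a methoxy group, an amine or a carboxylic acid, and whether a substituted phenyl would lower the number further.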